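This account rests on a few compounds, and the source may have more. Where it says the series, first, only, none or still open, it means among the compounds named here.

Working notes on the series. Compound 2 `N=C(S)CCn1ncccc1=S` is the starting point of this step. In a functional assay on the whole organism (stomach) with Rattus norvegicus as the target (on this read-out higher numbers stand for an effect only at larger amounts of compound and lower numbers for an effect already at smaller amounts), compound 2 gives 100 mg/kg, the larger of the two numbers in hand, a difference from compound 1 that lies within the scatter. Compound 1 `N=C(S)CCn1nc(-c2ccccc2)ccc1=S` carries a phenyl on the shared core; in this assay compound 1 gives 73.4 mg/kg, and the step of a 1.4-fold higher number from compound 1 to compound 2 (0.13 log units; within the scatter) is within the scatter. Compound 3 `Cc1cc(=O)n(CCC(=N)S)nc1-c1ccccc1` combines a methyl with a phenyl and an oxygen in place of the ring sulfur. In this assay compound 3 gives only a limit, > 100 mg/kg, which is the limit of > 100 mg/kg in this assay, at which 1 of the 3 values shown sits. Compound 4 `Cc1ccc(=S)n(CCC(=N)S)n1` is the compound to be measured next: methyl in place of hydrogen on an aromatic carbon. Among the measured compounds shown here, no measured step covers a methyl for a hydrogen on this core; the single measured step, a 1.4-fold higher number from compound 1 to compound 2 (0.13 log units; within the scatter), was within the scatter, so no step beyond the scatter is expected in this assay. For compound 4 the estimate is 100 mg/kg, with a range from 50 mg/kg to 200 mg/kg. This estimate corresponds to an expected step of no change at the digits printed from compound 2 to compound 4 (within the scatter).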

Compound 4, dose for half-maximal effect: 100 mg/kg
For compound 4 middle estimate and measured number coincide at the digits printed; measured number inside the range.
By their numbers in this assay, from the lowest: compounds 1, 2 and 4 (each within the scatter of the next).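

Among the compounds shown here, at this aromatic carbon the earlier compounds offered only phenyl against hydrogen; methyl in place of hydrogen now adds a small substituent to that comparison, with no change at the digits printed from compound 2 to compound 4 (within the scatter) in this assay. Methyl in place of phenyl gives a 1.4-fold higher number from compound 1 to compound 4 (0.13 log units; within the scatter), so hydrogen, methyl and phenyl at this carbon all lie within the scatter of one another in this assay, and neither the one carbon of methyl nor the whole phenyl ring separates from hydrogen. Compound 3 gives a limit, not a number: the limit of > 100 mg/kg in this assay, at which 1 of the 4 values shown sits.

Whether any group at this carbon gives a step beyond the scatter stays open, since an amine, a carboxylic acid and a longer chain such as propyl lie outside the compounds shown. Also open, from the compounds shown here alone, is whether methyl at this carbon gives the same result with a carbonyl in place of the ring sulfur.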